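Pendant phenyl substitution on the fused-core acid series

The compounds below may be only part of what the source reports. "The series", "measured", "known", "first", "only" and "open" are said of these compounds alone.

Compound 1 `CSc1ccc2c(Cc3cccc(C(=O)O)n3)c(-c3ccccc3)nn2c1` gives 87 nM in a functional assay on cells for antagonist activity at prostaglandin E2 receptor EP1 subtype (Rattus norvegicus), read by fluorescence and calcium flux, with a stated time of 60 s; on this read-out lower numbers stand for stronger inhibition and higher numbers for weaker inhibition. For the measured compounds named here, compound 2 `CS(=O)(=O)c1ccc2c(Cc3cccc(C(=O)O)n3)c(-c3ccccc3)nn2c1` gives 5400 nM in this assay, and the change a 62-fold higher number from compound 1 to compound 2 (1.79 log units; beyond the scatter) is the only single-point step measured so far. Compound 3 `O=C(O)c1cccc(Cc2c(-c3cccc(Cl)c3)nn3cc(Cl)ccc23)n1` gives 480 nM, the second highest of the three numbers: compound 1 stands lower and compound 2 higher, both beyond the scatter. Compound 4 `COc1ccc(-c2nn3cc(Cl)ccc3c2Cc2cccc(C(=O)O)n2)cc1` differs from compound 3 by 4-methoxyphenyl in place of 3-chlorophenyl on an aromatic carbon. Going by the values given here, the one measured step concerns the group on the fused core, not the pendant ring, so nothing measured bears directly on this change. For compound 4 the step expected is a 1.0-fold higher number from compound 3 to compound 4 (0.02 log units; within the scatter), within the scatter. Compound 4 is thus estimated at 500 nM, with a range of 150 nM to 2000 nM.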

Compound 4, half-maximal inhibitory concentration: 5400 nM
Estimate against measurement, compound 4: 11-fold (1.03 log units) below, and the stated range ends below it.
By their numbers in this assay, from the lowest: compound 1; then compound 3; then compounds 2 and 4 (each within the scatter of the next).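

The aromatic carbon bearing the pendant ring on the five-membered ring is a sensitive position: 4-methoxyphenyl in place of 3-chlorophenyl gives an 11-fold higher number from compound 3 to compound 4 (1.05 log units; beyond the scatter) in the chlorinated core. For the compounds shown here, the earlier compounds showed sensitivity only at the group on the fused core, so this is the first sign that the pendant ring matters as well. Nothing available explains this step.

Going by these compounds, it remains open whether the step follows the methoxy group, the loss of chlorine or the substituent's place on the ring. A pendant ring bearing fluorine or an amine would extend the comparison.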